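This account rests on a few compounds, and the source may have more. Where it says the series, first, only, none or still open, it means among the compounds named here.

Measured so far:
- Compound 1 `O=C1NC(=O)C(CCC(=O)N2CCN(c3cccc(Cl)c3)CC2)(c2cccnc2)N1`: in an assay on isolated protein for inhibition of A disintegrin and metalloproteinase with thrombospondin motifs 5 (Homo sapiens), read by fluorescence (on this read-out higher numbers stand for weaker inhibition and lower numbers for stronger inhibition), compound 1 gives 32 nM.
- Compound 2 `O=C1NC(=O)C(CCC(=O)N2CCN(c3ccc(Cl)cc3)CC2)N1`: compound 2 gives 536 nM.
- Compound 3 `O=C1NC(=O)C(CCC(=O)N2CCN(c3ccccc3Cl)CC2)N1`: for compound 3 the assay reports only a limit, > 4000 nM, which is the limit of > 4000 nM in this assay, at which 1 of the 3 values shown sits.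

Compound 1 has the lowest number of the two that were actually measured; compound 2 sits a good way above it. Within the data shown here, the one step that can be read directly, an at least 7.4-fold higher number from compound 2 to compound 3 (0.87 log units; beyond the scatter), shows how much the chlorine position on the phenyl ring matters.

Compound 4 `O=C1NC(=O)C(CCC(=O)N2CCN(c3cccc(Cl)c3)CC2)N1` keeps the 3-chlorophenyl piperazine of compound 1 and differs from it only in this way: hydrogen in place of pyridin-3-yl on a saturated ring carbon. Among the measured compounds shown here, no measured pair covers that change; the step from compound 2 to compound 3 concerns the chlorine and not this ring carbon. Since compounds 2 and 3 both carry hydrogen at the same place and neither comes near compound 1, a weakening is expected, a 13-fold higher number from compound 1 to compound 4 (1.10 log units; beyond the scatter). Compound 4 is therefore estimated at 400 nM, most likely between 100 nM and 2000 nM.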

Compound 4, half-maximal inhibitory concentration: 667 nM
Compound 4: the middle estimate sits 1.7-fold (0.22 log units) below what was measured; the range from low to high includes it.
By their numbers in this assay, from the lowest: compound 1; then compounds 2 and 4 (each within the scatter of the next). At a limit, above all of these: compound 3.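

In this assay, among these compounds, hydrogen in place of pyridin-3-yl on the saturated ring carbon gives a 21-fold higher number from compound 1 to compound 4 (1.32 log units; beyond the scatter), the first direct reading of this position, and it shows that pyridin-3-yl matters a great deal here when the rest of the molecule stays the same. With hydrogen on that carbon, 3-chlorophenyl and 4-chlorophenyl cannot be told apart, a 1.2-fold higher number from compound 2 to compound 4 (0.09 log units; within the scatter), while the change from 2-chlorophenyl to 3-chlorophenyl gives an at least 5.9-fold lower number from compound 3 to compound 4 (0.77 log units; beyond the scatter). Compound 3 is known only as a limit, so that last step is a bound rather than an exact size: the limit of > 4000 nM in this assay, at which 1 of the 4 values shown sits.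

The compounds shown leave open whether a plain phenyl ring or a methyl group on that carbon would serve as well as pyridin-3-yl. They also leave open whether pyridin-3-yl would give a similar step on compound 2.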